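Ester chain length in a quinazoline series: cytotoxicity notes

A few compounds are considered here, and "the series" means these few. Any claim that something is new, unique, unknown or untested is made for them only; others in the source may bear on it.

Of the compounds shown here, two of the shared core have been measured in a functional assay on A549 cells (Homo sapiens) for cytotoxicity, read by MTT assay, with a stated time of 24 h, tested at 20 uM; on this read-out lower numbers stand for a stronger effect and higher numbers for a weaker effect at the one concentration tested. Compound 1 `CCCCCOC(=O)CCC(=O)N1CCN(CCCOc2cc3c(Nc4ccc(F)c(Cl)c4)ncnc3cc2OC)CC1` gives 81.2% in this assay, and compound 2 `CCCCCCCCCCCOC(=O)CCC(=O)N1CCN(CCCOc2cc3c(Nc4ccc(F)c(Cl)c4)ncnc3cc2OC)CC1` gives 85.2% in this assay, so the two numbers sit close together. Within the data shown here, the single step between them, a number 4 percentage points higher from compound 1 to compound 2 (within the scatter), is the only one available for comparison. Compound 3 `CCCCCCCCCCCCCCCOC(=O)CCC(=O)N1CCN(CCCOc2cc3c(Nc4ccc(F)c(Cl)c4)ncnc3cc2OC)CC1` is not yet measured; it differs from compound 2 by butyl in place of hydrogen on a saturated chain carbon, ten or more bonds along the chain from an oxygen next to a carbonyl group. This lengthening of the same ester chain is of the same kind as the step from compound 1 to compound 2, and that step stayed inside the scatter. Among the measured compounds shown here, no step so far moves this read-out beyond the scatter, so no shift beyond the scatter is expected for compound 3 either. Compound 3 is therefore estimated at 86% in this assay, within a range of 74% to 97%. The expected step of a number 0.8 percentage points higher from compound 2 to compound 3 (within the scatter) is small.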

Compound 3, a percentage reported as activity, at one concentration (the size of the read-out at that concentration, not a potency): 91.2%
Compound 3: the middle estimate sits 5.2 percentage points below what was measured, within the range that was stated.
By their numbers in this assay, from the lowest: compounds 1, 2 and 3 (each within the scatter of the next).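

Working from the butyl step, a number 6 percentage points higher from compound 2 to compound 3 (within the scatter) in this assay, the ester chain at this position still gives no step beyond the scatter when it reaches its longest form in the series. The widest span now available, a number 10 percentage points higher from compound 1 to compound 3 (within the scatter), also stays inside the scatter, so the three compounds cannot be separated in this read-out, even with decyl as the full difference. Nothing measured here accounts for this behaviour of the chain.

As far as these compounds go, it remains open whether a shorter chain, such as methyl or ethyl, would give a step beyond the scatter in this read-out. Also open, from the compounds shown here alone, is whether an amine or a carboxylic acid in place of the ester chain would do so.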